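A few compounds are considered here, and "the series" means these few. Any claim that something is new, unique, unknown or untested is made for them only; others in the source may bear on it.

In a functional assay on SW 1116 cells (Homo sapiens) for antiproliferative activity, read by MTT assay, with a stated time of 24 h (a lower number here means a stronger inhibitor, a higher number a weaker inhibitor), compound 1 `Sc1nnc(-c2ccc3c(c2)OCCO3)n1-c1ccccc1` gives 38400 nM, compound 2 `Cc1ccc(CSc2nnc(-c3ccc4c(c3)OCCO4)n2-c2ccccc2)cc1` gives 16200 nM and compound 3 `Fc1ccccc1CSc1nnc(-c2ccc3c(c2)OCCO3)n1-c1ccccc1` gives 13600 nM. Compound 3 holds the lowest of the three numbers; the step nearest to it is a 1.2-fold lower number from compound 2 to compound 3 (0.08 log units; within the scatter), the furthest is a 2.8-fold lower number from compound 1 to compound 3 (0.45 log units; beyond the scatter). The two larger steps, a 2.4-fold lower number from compound 1 to compound 2 (0.37 log units; beyond the scatter) and a 2.8-fold lower number from compound 1 to compound 3 (0.45 log units; beyond the scatter), come from placing a benzyl group on a sulfur, not from a change on the aryl ring. Compound 4 `Fc1ccc(CSc2nnc(-c3ccc4c(c3)OCCO4)n2-c2ccccc2)c(F)c1` differs from compound 3 by fluoro in place of hydrogen on an aromatic carbon. Among the measured compounds shown here, the one measured step that alters the substitution of that ring, a 1.2-fold lower number from compound 2 to compound 3 (0.08 log units; within the scatter), lay within the scatter, so in this assay no step beyond the scatter is expected here either, estimated as a 1.1-fold lower number from compound 3 to compound 4 (0.05 log units; within the scatter). Compound 4 is therefore expected to give 12000 nM, between 6000 nM and 25000 nM.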

Compound 4, half-maximal inhibitory concentration: 7830 nM
Compound 4: middle estimate off by 1.5-fold (0.19 log units), on the high side; low and high end bracket the measured number.
By their numbers in this assay, from the lowest: compounds 4, 3 and 2 (each within the scatter of the next, the first and the last beyond it); then compound 1.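

In this assay, fluoro in place of hydrogen, para to a large group and meta to a fluoro group, gives only a 1.7-fold lower number from compound 3 to compound 4 (0.24 log units; within the scatter) and so stays within the scatter on its own. Even so, the 2,4-difluorobenzyl group clears the scatter against the 4-methylbenzyl group, with a 2.1-fold lower number from compound 2 to compound 4 (0.32 log units; beyond the scatter) where compound 3 did not, and hydrogen on the sulfur now gives way to a 4.9-fold lower number from compound 1 to compound 4 (0.69 log units; beyond the scatter) as the step for this group. No available evidence accounts for these steps.

Still open, from the compounds shown here alone, is whether chloro, methoxy, an amine or a carboxylic acid at this ring position would give a step beyond the scatter. Going by these compounds, a longer chain in place of the benzyl group also remains untested in these compounds.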